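Replacing pyridin-3-yl with 4-fluorophenyl on the carbonyl

The source may report more compounds than this note shows. Statements on the series, on what has been measured and on what is new or still open speak of the compounds shown alone.

Three compounds share one core and differ only in the ring attached to the carbonyl carbon. In a functional assay on MDA-MB-231 cells (Homo sapiens) for cytotoxicity, read by MTT assay, with a stated time of 48 h (a higher number here means a weaker inhibitor, a lower number a stronger inhibitor), compound 1 `O=C(/C=C/c1ccc2c(c1)B(O)OC2)c1ccc(-c2ccccc2)cc1` gives 6400 nM, compound 2 `O=C(/C=C/c1ccc2c(c1)B(O)OC2)c1ccco1` gives 7300 nM, and compound 3 `O=C(/C=C/c1ccc2c(c1)B(O)OC2)c1cccnc1` gives 11400 nM. Compound 3 thus shows the highest of the three numbers, yet its gaps to compound 2 and to compound 1 both fall within the usual scatter. Compound 4 `O=C(/C=C/c1ccc2c(c1)B(O)OC2)c1ccc(F)cc1` differs from compound 3 in one place: 4-fluorophenyl in place of pyridin-3-yl on a carbonyl carbon. Within the data shown here, the only measured step at this position, a 1.6-fold higher number from compound 2 to compound 3 (0.19 log units; within the scatter), stayed within the scatter, as did the spread across all three rings, so no change beyond the scatter is expected for compound 4. Compound 4 is therefore expected near 8000 nM, within a range from 3500 nM to 18000 nM, an expected step of a 1.4-fold lower number from compound 3 to compound 4 (0.15 log units; within the scatter).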

Compound 4, half-maximal inhibitory concentration: 1600 nM
Compound 4: the middle estimate sits 5.0-fold (0.70 log units) above what was measured; measured number outside the range, below it.
By their numbers in this assay, from the lowest: compound 4; then compounds 1, 2 and 3 (each within the scatter of the next).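

In this assay the ring on the carbonyl carbon turns out to matter: a 7.1-fold lower number from compound 3 to compound 4 (0.85 log units; beyond the scatter) lies beyond the scatter, which no gap among the earlier rings did. The other two rings point the same way, with a 4.6-fold lower number from compound 2 to compound 4 (0.66 log units; beyond the scatter) and a 4.0-fold lower number from compound 1 to compound 4 (0.60 log units; beyond the scatter) also beyond the scatter, the last being fluoro in place of phenyl on an aromatic carbon. Nothing available here accounts for this gain.

Still open, going by these compounds, is whether a plain phenyl, a 4-chlorophenyl or a 4-methoxyphenyl on the same carbonyl would match compound 4, so the part played by the fluoro itself remains unknown.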